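Urea and amide variants on the shared core: cytotoxicity notes

The source may report more compounds than this note shows. Statements on the series, on what has been measured and on what is new or still open speak of the compounds shown alone.

Compound 1 `COc1cc(-c2nn(-c3cccc(NC(=O)Nc4ccc(Cl)c(Cl)c4)c3)cc2-c2ccncc2)ccc1Cl` gives in a functional assay on A498 cells (Homo sapiens) for inhibition, read by sulforhodamine B assay, with a stated time of 48 h (on this read-out lower numbers stand for higher toxicity in this test and higher numbers for lower toxicity in this test), only the limit > 50000 nM.
Compound 2 `COc1cc(-c2nn(-c3cccc(NC(=O)c4ccc(Cl)c(C(F)(F)F)c4)c3)cc2-c2ccncc2)ccc1Cl` gives in this assay only the limit > 32500 nM.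

Compound 2 stands at the limit of > 32500 nM in this assay, at which 1 of the 2 values shown sits. Compound 1 stands at the limit of > 50000 nM in this assay, at which 1 of the 2 values shown sits. Among the compounds with values here, the one measured step, a step that the two limits leave unreadable from compound 1 to compound 2, is therefore not readable as a number. Compound 3 `COc1cc(-c2nn(-c3cccc(NC(=O)Nc4ccc(Cl)c(C(F)(F)F)c4)c3)cc2-c2ccncc2)ccc1Cl` carries (4-chloro-3-(trifluoromethyl)phenyl)amino in place of 4-chloro-3-(trifluoromethyl)phenyl on a carbonyl carbon, restoring the urea of compound 1 while keeping the aryl group of compound 2. Both neighbours sit at limits, so no step beyond the scatter is expected. Compound 3 is estimated at 50000 nM, range 20000 nM to 100000 nM, an expected step that the limit leaves unreadable from compound 2 to compound 3, most likely again reported as a limit.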

Compound 3, concentration lethal to 50% of the cells: > 32500 nM
Compound 3 gave a limit, no number; the forecaster's own chance of this, stated with the estimate: 85%; the middle value lies beyond the limit too.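

Compound 3 gives in this assay only the limit > 32500 nM. Within the data shown here, no step to compound 3 from compound 1 or compound 2 can be read. The compounds shown leave open whether the urea or amide variants differ at all in this assay.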